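Catechol cinnamate amides: from morpholine to chlorophenyl

This account rests on a few compounds, and the source may have more. Where it says the series, first, only, none or still open, it means among the compounds named here.

Among the measured compounds shown here, compound 1 `COc1ccc(NC(=O)COC(=O)/C=C/c2cc(OC)c(OCc3ccc(Cl)c(Cl)c3)c(OC)c2)cc1` is the only member with a number: in a functional assay on BEL-7404 cells (Homo sapiens) for cytotoxicity, read by MTT assay, with a stated time of 72 h (on this read-out lower numbers stand for stronger inhibition and higher numbers for weaker inhibition), compound 1 gives 97800 nM. Compound 2 `O=C(COC(=O)/C=C/c1ccc(O)c(O)c1)NN1CCOCC1` sits at a limit, since in this assay compound 2 gives only > 200000 nM. That limit is the limit of > 200000 nM in this assay, at which 1 of the 2 values shown sits, so compound 2 stands at the weak end of what is shown. Compound 3 `O=C(COC(=O)/C=C/c1ccc(O)c(O)c1)Nc1ccc(Cl)cc1` differs from compound 2 by 4-chlorophenyl in place of morpholin-4-yl on an amide-type nitrogen, a change toward the amide seen in compound 1. Without a measured step to lean on, the step from compound 2 to compound 3 is expected to be modest, an at least 1.3-fold lower number from compound 2 to compound 3 (0.12 log units; that floor lies within the scatter), perhaps toward stronger inhibition. Compound 3 is thus estimated at 150000 nM, within 50000 nM to 400000 nM.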

Compound 3, half-maximal inhibitory concentration: > 200000 nM
Compound 3 was reported as a limit (the forecaster's own chance of this, stated with the estimate: 45%); at least 1.3-fold (0.12 log units) between middle value and limit.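

In this assay compound 3 gives only a limit, > 200000 nM. Among the compounds shown here, compound 2 is also a limit, so no step from compound 2 to compound 3 can be read. From the compounds shown here alone, whether 4-chlorophenyl in place of morpholin-4-yl shifts the read-out at all stays open.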